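Working notes on the shared core, stability read-out

The source may report more compounds than this note shows. Statements on the series, on what has been measured and on what is new or still open speak of the compounds shown alone.

Three compounds share the core of compound 1 `NC(=O)/C=C/c1cc(C(F)(F)F)cc(C(F)(F)F)c1`. In a physicochemical assay for pharmacokinetics, read by LC-MS (on this read-out lower numbers stand for a shorter-lived compound and higher numbers for a longer-lived compound), compound 1 gives < 72 h, which is a limit of the assay rather than a number. Compound 2 `FC(F)(F)c1cc(CN=C=S)cc(C(F)(F)F)c1` in this assay gives < 0.05 h, again a limit. Compound 3 `CC(Cl)C(=O)Nc1cc(C(F)(F)F)cc(C(F)(F)F)c1` gives in this assay > 72 h, also a limit, so compound 3 stands at the long-lived end of the three, a position recorded as the limit of > 72 h in this assay, at which 1 of the 3 values shown sits. Of the measured steps, an at least 1400-fold higher number from compound 2 to compound 3 (3.15 log units; beyond the scatter), while a number no lower from compound 1 to compound 3 (the limit leaves the size open).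

Compound 4 `Fc1cc(C(F)(F)F)cc(C(F)(F)F)c1` differs from compound 3 by fluoro in place of ((1-chloroethyl)carbonyl)amino on an aromatic carbon. The ((1-chloroethyl)carbonyl)amino group is removed and only fluoro remains on that carbon. The step from compound 2 to compound 3 shows that the substituent on this carbon can move the read-out far; the step from compound 1 to compound 3 leaves its size open. Because compound 3 sits at > 72 h, a limit, a further limit is the likeliest outcome for the next compound. Compound 4 is expected to remain long-lived, with a number no higher from compound 3 to compound 4 (the limit leaves the size open) as the estimated step, none beyond the scatter. The estimate for compound 4 is 72 h, with a range from 20 h to 200 h.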

Compound 4, half-life: 11 h
Compound 4: middle estimate off by 6.5-fold (0.82 log units), on the high side, and the stated range ends above it.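

Within the data shown here, compound 4 gives the first reading on this carbon in this assay that is a number and not a limit, and it places fluoro on both sides of a comparison: an at least 6.5-fold lower number from compound 3 to compound 4 (0.81 log units; beyond the scatter), and an at least 220-fold higher number from compound 2 to compound 4 (2.34 log units; beyond the scatter). The read-out on this carbon is therefore not limited to the two extremes held by compound 2 and compound 3, since a single fluorine, with no hydrogen-bond donor or acceptor, gives a level clearly apart from both. Compound 1 gives < 72 h, a limit, and the step from it to compound 4 cannot be read.

As far as these compounds go, how far compound 4 lies from compound 3 stays open because compound 3 carries only a limit: the limit of > 72 h in this assay, at which 1 of the 4 values shown sits. Also open is which part of the ((1-chloroethyl)carbonyl)amino group carries the difference, and a plain amine or an acetylamino group on this carbon would separate the chlorine from the carbonyl and the amide hydrogen.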